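The source may hold more compounds than are shown below. What is called first, only, known or untested is meant among the compounds shown, and "the series" means these compounds.

For the measured compounds named here, compound 2 `CN(C)CCCNc1nc(-c2ccc(NC(=O)Nc3ccccc3Cl)cc2)nc2ccsc12` gives 430 nM in a functional assay on NCI-H460 cells (Homo sapiens) for cytotoxicity, read by MTT assay, with a stated time of 72 h (a higher number here means a weaker inhibitor, a lower number a stronger inhibitor), one of only two numbers so far; the other belongs to compound 1 `CN(C)CCCNc1nc(-c2ccc(NC(=O)Nc3ccccc3F)cc2)nc2ccsc12` at 530 nM, and the two lie within the scatter of each other. Compound 3 `CN(C)CCCNc1nc(-c2ccc(NC(=O)Nc3ccc(Cl)cc3Cl)cc2)nc2ccsc12` differs from compound 2 by chloro in place of hydrogen on an aromatic carbon. Going by the values given here, the single measured step, a 1.2-fold lower number from compound 1 to compound 2 (0.09 log units; within the scatter), swapped one halogen for another and stayed within the scatter, so it gives little guidance on adding a second chloro. No step beyond the scatter is therefore expected in this assay. Compound 3 is estimated at 400 nM, within 180 nM to 900 nM. That expectation corresponds to a 1.1-fold lower number from compound 2 to compound 3 (0.03 log units; within the scatter).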

Compound 3, half-maximal inhibitory concentration: 1020 nM
For compound 3 the middle estimate is 2.6-fold (0.41 log units) below the measured one, and the stated range ends below it.
By their numbers in this assay, from the lowest: compounds 2, 1 and 3 (each within the scatter of the next, the first and the last beyond it).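

In this assay, adding a second chloro to give the 2,4-dichlorophenyl group produces a 2.4-fold higher number from compound 2 to compound 3 (0.38 log units; beyond the scatter) and so weakens the compound, which the halogen swap did not do; the place para to a large group is therefore sensitive to change. For the compounds shown here, the other comparison stays within the scatter (a 1.9-fold higher number from compound 1 to compound 3 (0.28 log units; within the scatter)), so this loss shows clearly against only one neighbour. Nothing measured here explains the loss. On these data alone, whether it is specific to chloro or would follow any added group remains open, and a methoxy group or an amine in that place would help to settle this.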